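Aryl swap on the shared core: furan-2-yl to pyridin-4-yl

The source may hold more compounds than are shown below. What is called first, only, known or untested is meant among the compounds shown, and "the series" means these compounds.

Measured in a functional assay on NCI-H460 cells (Homo sapiens) for inhibition, with a stated time of 72 h; on this read-out lower numbers stand for stronger inhibition and higher numbers for weaker inhibition:
- compound 1 `COc1ccc(S(=O)(=O)N2CCc3cccc(-c4ccc(N)cc4)c32)cc1`: 288 nM
- compound 2 `COc1ccc(S(=O)(=O)N2CCc3cccc(-c4ccco4)c32)cc1`: 94.5 nM
- compound 3 `COc1ccc(S(=O)(=O)N2CCc3cccc(-c4ccc(F)cc4)c32)cc1`: 95.5 nM

Compound 2 shares the low end of these three numbers with compound 3. Replacing furan-2-yl with 4-fluorophenyl gives a 1.0-fold higher number from compound 2 to compound 3 (0.00 log units; within the scatter). The 4-aminophenyl member lies apart from both, with a 3.0-fold lower number from compound 1 to compound 2 (0.48 log units; beyond the scatter) and a 3.0-fold lower number from compound 1 to compound 3 (0.48 log units; beyond the scatter).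

The open question is compound 4 `COc1ccc(S(=O)(=O)N2CCc3cccc(-c4ccncc4)c32)cc1`, which departs from compound 2 as follows: pyridin-4-yl in place of furan-2-yl on an aromatic carbon. Among the compounds with values here, no measured compound carries pyridin-4-yl, so the evidence is indirect. Within the data shown here, the closest precedent is the exchange of furan-2-yl for a six-membered aromatic ring, where a 1.0-fold higher number from compound 2 to compound 3 (0.00 log units; within the scatter) shows no step beyond the scatter. The modest step of a 3.0-fold lower number from compound 1 to compound 3 (0.48 log units; beyond the scatter) shows that a change on that six-membered ring can matter, so the upper side of the range stays wide. In this assay, no step beyond the scatter is expected, and the estimated step is a 1.1-fold higher number from compound 2 to compound 4 (0.02 log units; within the scatter). For compound 4 the expected value is 100 nM, with an estimated range of 35 nM to 290 nM.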

Compound 4, half-maximal inhibitory concentration: 101 nM
For compound 4 the middle estimate is 1.0-fold (0.00 log units) below the measured one, within the range that was stated.
By their numbers in this assay, from the lowest: compounds 2, 3 and 4 (each within the scatter of the next); then compound 1.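

In this assay the aromatic carbon of the shared core now also carries a ring with a nitrogen hetero atom: a 1.1-fold higher number from compound 2 to compound 4 (0.03 log units; within the scatter) and a 1.1-fold higher number from compound 3 to compound 4 (0.02 log units; within the scatter) leave pyridin-4-yl indistinguishable from furan-2-yl and 4-fluorophenyl. Within the data shown here, with a 2.9-fold lower number from compound 1 to compound 4 (0.46 log units; beyond the scatter) in the same assay, compound 1 stays the one member set apart, so a ring hetero atom in the six-membered aryl group does not by itself reproduce the gap seen with 4-aminophenyl. Nothing available explains why these three groups read alike or why 4-aminophenyl stands apart.

Open, on these data alone, is whether pyridin-3-yl or pyridin-2-yl would read like pyridin-4-yl. Also open, as far as these compounds go, is whether a saturated ring such as piperidin-4-yl, or a carboxylic acid on the phenyl ring in place of the amino group, would keep the number at this level.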